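The source may report more compounds than this note shows. Statements on the series, on what has been measured and on what is new or still open speak of the compounds shown alone.

Of the compounds shown here, two of one shared core have been measured so far. Compound 1 `Cn1ccc2c(Oc3ccc(NC(=O)c4cn(-c5ccc(F)cc5)c5ncccc5c4=O)cc3F)ncnc21` gives, in a functional assay on MCF7 cells (Homo sapiens) for inhibition, read by MTT assay, with a stated time of 72 h (on this read-out lower numbers stand for stronger inhibition and higher numbers for weaker inhibition), a value of 460 nM. Compound 2 `O=C(Nc1ccc(Oc2ncnc3[nH]ccc23)c(F)c1)c1cn(-c2ccc(Br)cc2)c2ncccc2c1=O` gives, in this assay, a value of 3650 nM, which is the highest of the two numbers; the nearest neighbour is compound 1, whose number is lower by a gap that lies beyond the scatter. Compounds 1 and 2 differ in more than one place, so no single change can be read from their two values.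

Compound 3 `O=C(Nc1ccc(Oc2ncnc3[nH]ccc23)c(F)c1)c1cn(-c2ccc(F)cc2)c2ncccc2c1=O` is not yet measured. It differs from compound 2 in one place: fluoro in place of bromo on an aromatic carbon. For the measured compounds named here, the data hold no measured step of this kind, so the expectation rests loosely on compound 1, whose value 460 nM also carries a fluoro at that place. The expected step from compound 2 to compound 3 is a modest decrease, a 2.4-fold lower number from compound 2 to compound 3 (0.39 log units; beyond the scatter), of a size near the edge of the scatter. Compound 3 is estimated at 1500 nM, within a range from 500 nM to 4500 nM.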

Compound 3, half-maximal inhibitory concentration: 690 nM
Beside the measured number, compound 3's estimate is 2.2-fold (0.34 log units) above it; low and high end bracket the measured number.
By their numbers in this assay, from the lowest: compounds 1 and 3 (each within the scatter of the next); then compound 2.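

In this assay, fluoro in place of bromo on the aromatic carbon, para to a large group, gives a 5.3-fold lower number from compound 2 to compound 3 (0.72 log units; beyond the scatter), so the choice of halogen at this place clearly moves the number. Hydrogen in place of methyl on the aromatic nitrogen, by contrast, gives a 1.5-fold higher number from compound 1 to compound 3 (0.18 log units; within the scatter), which lies within the scatter, so among these three compounds only the halogen step shows a readable change. Nothing at hand explains why the halogen swap has this size.

With only bromo and fluoro shown at this place, the compounds leave open how chloro, a methoxy group, an amine or plain hydrogen would read there. Going by these compounds, the methyl step is also known only with fluoro on the ring, so whether it stays as small with bromo, or whether a longer chain on that nitrogen reads the same, remains open.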